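This account rests on a few compounds, and the source may have more. Where it says the series, first, only, none or still open, it means among the compounds named here.

Compound 3 `CCN(CC)C(=O)CCC(=O)Oc1ccc(C[C@H]2C(=O)OC[C@@H]2Cc2ccc(OC)c(OC)c2)cc1OC` carries the highest number of the three in an ADME assay on HeLa cells (Homo sapiens) for cytotoxicity, read by MTT assay (a higher number here means a weaker inhibitor, a lower number a stronger inhibitor), where compound 3 gives 213000 nM. Compound 1 `COc1ccc(C[C@H]2COC(=O)[C@@H]2Cc2ccc(OC(=O)CCC(=O)N3CCCCC3)c(OC)c2)cc1OC` gives 128000 nM there, a step of a 1.7-fold higher number from compound 1 to compound 3 (0.22 log units; within the scatter). Compound 2 `COC(=O)[C@@H](NC(=O)CCC(=O)Oc1ccc(C[C@H]2C(=O)OC[C@@H]2Cc2ccc(OC)c(OC)c2)cc1OC)C(C)C` gives 64000 nM, a step of a 3.3-fold higher number from compound 2 to compound 3 (0.52 log units; beyond the scatter). Compound 4 `COC(=O)CNC(=O)CCC(=O)Oc1ccc(C[C@H]2C(=O)OC[C@@H]2Cc2ccc(OC)c(OC)c2)cc1OC` differs from compound 3 in one place: ((methoxycarbonyl)methyl)amino in place of diethylamino on a carbonyl carbon. The step of a 3.3-fold higher number from compound 2 to compound 3 (0.52 log units; beyond the scatter) bears most directly on this change, compound 2 carrying the related (1-(methoxycarbonyl)-2-methylpropyl)amino group on the same carbonyl carbon; the step of a 1.7-fold higher number from compound 1 to compound 3 (0.22 log units; within the scatter) adds little. Running the change from compound 2 in reverse, a modest lower number is expected for compound 4, a 2.5-fold lower number from compound 3 to compound 4 (0.40 log units; beyond the scatter). Compound 4 is therefore estimated at 85000 nM, within a range of 30000 nM to 240000 nM.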

Compound 4, half-maximal inhibitory concentration: 179000 nM
Beside the measured number, compound 4's estimate is 2.1-fold (0.32 log units) below it; measured number inside the range.
By their numbers in this assay, from the lowest: compounds 2, 1, 4 and 3 (each within the scatter of the next, the first and the last beyond it).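

In this assay, ((methoxycarbonyl)methyl)amino on this carbonyl carbon reads no differently from diethylamino (a 1.2-fold lower number from compound 3 to compound 4 (0.08 log units; within the scatter)) or from piperidin-1-yl (a 1.4-fold higher number from compound 1 to compound 4 (0.15 log units; within the scatter)). Hydrogen in place of isopropyl on the saturated chain carbon bound to an amide-type nitrogen and a carbonyl carbon is the one new step beyond the scatter (a 2.8-fold higher number from compound 2 to compound 4 (0.45 log units; beyond the scatter)), so among these compounds the modest difference tracks that isopropyl group. No evidence on hand accounts for this step.

Still open, on these data alone, is whether a free carboxylic acid in place of the methyl ester, or a longer chain in place of isopropyl, would move the number.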